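The compounds below may be only part of what the source reports. "The series", "measured", "known", "first", "only" and "open" are said of these compounds alone.

Three compounds share one core and differ only in the chain attached to the oxygen on the aromatic ring. Compound 1 `CCCCOc1ccc2c(Cl)ccnc2c1` carries a butyl chain, compound 2 `CCCCCCCCOc1ccc2c(Cl)ccnc2c1` an octyl chain, and compound 3 `CCCCCCOc1ccc2c(Cl)ccnc2c1` a hexyl chain. In a functional assay on HepG2 cells (Homo sapiens) for cytotoxicity, read by MTT assay, with a stated time of 48 h (a higher number here means a weaker inhibitor, a lower number a stronger inhibitor), compound 1 gives 2640 nM, compound 2 gives 2640 nM, and compound 3 gives 2420 nM. Compound 3 shows the smallest number of the three, but the gaps to the other two lie within the scatter: the step of a 1.1-fold lower number from compound 1 to compound 3 (0.04 log units; within the scatter) and the step of a 1.1-fold lower number from compound 2 to compound 3 (0.04 log units; within the scatter) are both tiny, as is no change at the digits printed from compound 1 to compound 2 (within the scatter). Compound 4 `CCOc1ccc2c(Cl)ccnc2c1` shortens the chain further, a change that reads as hydrogen in place of butyl on a saturated chain carbon, two bonds along the chain from an oxygen on an aromatic ring. All three measured steps concern the length of this same chain, and none of them moved the number beyond the scatter. On that basis the step of a 1.0-fold higher number from compound 3 to compound 4 (0.01 log units; within the scatter) is expected to be small. Compound 4 is therefore estimated at 2500 nM in this assay, with a range from 1200 nM to 5200 nM.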

Compound 4, half-maximal inhibitory concentration: 2660 nM
Compound 4: the middle estimate sits 1.1-fold (0.03 log units) below what was measured; low and high end bracket the measured number.
By their numbers in this assay, from the lowest: compounds 3, 1, 2 and 4 (each within the scatter of the next).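

Compound 4 carries the shortest chain of the four, an ethyl, and in this assay it still sits level with the others: the steps are a 1.1-fold higher number from compound 3 to compound 4 (0.04 log units; within the scatter), a 1.0-fold higher number from compound 2 to compound 4 (0.00 log units; within the scatter) and a 1.0-fold higher number from compound 1 to compound 4 (0.00 log units; within the scatter). Adding butyl to the chain gives matching steps whether it starts from butyl or from ethyl: the same change on two cores in this assay, no change at the digits printed (within the scatter) from compound 1 to compound 2 and a 1.1-fold lower number (0.04 log units; within the scatter) from compound 4 to compound 3, 1.1-fold (0.04 log units) apart, within the scatter of two such steps Removing a longer stretch of chain gives matching steps too, so across ethyl, butyl, hexyl and octyl no compound goes against a flat picture at this position: the same change on two cores in this assay, a 1.1-fold lower number (0.04 log units; within the scatter) from compound 2 to compound 3 and a 1.0-fold higher number (0.00 log units; within the scatter) from compound 1 to compound 4, 1.1-fold (0.04 log units) apart, within the scatter of two such steps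

As far as these compounds go, it remains open whether a chain longer than octyl, or a chain ending in an amine or a carboxylic acid, would move the number beyond the scatter. A bare hydroxyl in place of the chain is equally untested among the compounds shown.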